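Swapping a thiophene for a methoxyphenoxy group on the aryl arm

The compounds below may be only part of what the source reports. "The series", "measured", "known", "first", "only" and "open" are said of these compounds alone.

Going by the values given here, compound 2 `Cc1ccccc1-n1nc(C)c2c1NC(=O)[C@H](C)S[C@@H]2c1ccc(-c2ccsc2)cc1` stands highest of the two numbers measured so far: in an assay on isolated protein for agonist activity at Bile acid receptor (Homo sapiens), read by AlphaScreen, with a stated time of 30 min (a higher number here means a larger maximal response, a lower number a smaller maximal response), compound 2 gives 68%. Among the compounds with values here, its nearest neighbour, compound 1 `Cc1ccccc1-n1nc(C)c2c1NC(=O)[C@H](C)S[C@@H]2c1ccc(-c2ccoc2)cc1`, gives 40% in this assay, and the single measured step, a number 28 percentage points higher from compound 1 to compound 2 (beyond the scatter), comes from exchanging one five-membered ring for another at the same aromatic carbon.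

Compound 3 `COc1ccccc1Oc1ccc([C@H]2S[C@@H](C)C(=O)Nc3c2c(C)nn3-c2ccccc2C)cc1` departs from compound 2 by the change (2-methoxyphenoxy in place of thiophen-3-yl on an aromatic carbon). Within the data shown here, the only step on record, a number 28 percentage points higher from compound 1 to compound 2 (beyond the scatter), bears on it weakly: it shows that this position tolerates a change of ring with a modest shift, but the entering group is a six-membered ring joined through an oxygen, for which no precedent exists here. Compound 3 is therefore expected to move by a number 13 percentage points lower from compound 2 to compound 3 (beyond the scatter) in this assay, with wide uncertainty. The estimate for compound 3 is 55%, within a range of 25% to 85%.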

Compound 3, largest response reached (reported as efficacy), in percent of the reference or control that the assay uses: 240%
Compound 3: middle estimate off by 185 percentage points, on the low side, outside the stated range (above it).
By their numbers in this assay, from the lowest: compound 1; then compound 2; then compound 3.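

Placing 2-methoxyphenoxy on this aromatic carbon gives a number 172 percentage points higher from compound 2 to compound 3 (beyond the scatter) in this assay, and measured against the furan-3-yl group it gives a number 200 percentage points higher from compound 1 to compound 3 (beyond the scatter), so the response at this position is not limited to what the two five-membered rings reached. Compound 3 stands highest of the three, with its steps to both others beyond the scatter, and the earlier ring exchange, a number 28 percentage points higher from compound 1 to compound 2 (beyond the scatter), now covers only a small part of the range seen at this position. Nothing at hand accounts for the size of this step.

The oxygen link, the six-membered ring and the methoxy group all enter together in compound 3, so the compounds shown do not tell which of them carries the step. As far as these compounds go, it also stays open whether a plain phenoxy group, or a phenoxy ring bearing an amine or a carboxylic acid instead of the methoxy group, would keep this response.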